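The compounds below may be only part of what the source reports. "The series", "measured", "known", "first", "only" and "open" are said of these compounds alone.

Compound 1 `COc1cccc(S(=O)(=O)Nc2cccc(-c3nc(-c4ccc(NC(=O)c5cccnc5)cc4Cl)no3)c2)c1`: in a functional assay on MDA-MB-231 cells (Homo sapiens) for antiproliferative activity, read by MTT assay, with a stated time of 72 h (a lower number here means a stronger inhibitor, a higher number a weaker inhibitor), compound 1 gives > 10000 nM, which is a limit of the assay, not a number.
Compound 2 `CC(=O)Nc1ccc(S(=O)(=O)Nc2cccc(-c3nc(-c4ccc(NC(=O)c5cccnc5)cc4Cl)no3)c2)cc1C`: compound 2 gives > 10000 nM, again a limit.
Compound 3 `CCNC(=O)Nc1ccc(S(=O)(=O)Nc2cccc(-c3nc(-c4ccc(NC(=O)c5cccnc5)cc4Cl)no3)c2)cc1`: compound 3 gives 3100 nM.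

Compound 1 therefore stands at the limit, (the limit of > 10000 nM in this assay, at which 2 of the 3 values shown sit), and only compound 3 gives a readable number. The steps among the measured compounds all keep the sulfonamide and vary the ring on the sulfonyl sulfur: a step that the two limits leave unreadable from compound 1 to compound 2; an at least 3.2-fold lower number from compound 1 to compound 3 (0.50 log units; beyond the scatter); an at least 3.2-fold lower number from compound 2 to compound 3 (0.50 log units; beyond the scatter).

Compound 4 `COc1ccc(NC(=O)Nc2cccc(-c3nc(-c4ccc(NC(=O)c5cccnc5)cc4Cl)no3)c2)cc1` takes a different route: (4-methoxyphenyl)carbamoyl in place of (3-methoxyphenyl)sulfonyl on a nitrogen on an aromatic ring. Within the data shown here, no measured step touches this place, since the linker itself is exchanged rather than the ring it carries, so the three steps give no direct guide. The only readable gain among the measured compounds came with a urea, in compound 3, but on a different part of the molecule. The expectation for compound 4 is a modest step below the limit, an at least 2.0-fold lower number from compound 1 to compound 4 (0.30 log units; that floor lies within the scatter), held with little confidence. Compound 4 is estimated at 5000 nM, between 1500 nM and 20000 nM.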

Compound 4, half-maximal inhibitory concentration: 3000 nM
For compound 4 the middle estimate is 1.7-fold (0.22 log units) above the measured one; low and high end bracket the measured number.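

In this assay, exchanging the linker itself gives an at least 3.3-fold lower number from compound 1 to compound 4 (0.52 log units; beyond the scatter), so this nitrogen on an aromatic ring can carry a carbamoyl group in place of a sulfonyl group and still give a readable number. The size of this step is only a floor because compound 1 stands at a limit, not at a number: the limit of > 10000 nM in this assay, at which 2 of the 4 values shown sit.
The step also replaces (3-methoxyphenyl)sulfonyl with (4-methoxyphenyl)carbamoyl, so the linker and the placing of the methoxy group change together, and this one step does not separate them.

As far as these compounds go, what (3-methoxyphenyl)carbamoyl or (4-methoxyphenyl)sulfonyl would give at this place, which could separate the two changes, stays open. So does the result of an amine or a carboxylic acid in place of the methoxy group on the carbamoyl ring.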